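Working notes: from compound 3 to compound 4

The compounds below may be only part of what the source reports. "The series", "measured", "known", "first", "only" and "open" are said of these compounds alone.

Measured in an ADME assay on L1210/0 cells (Mus musculus) for cytotoxicity, with a stated time of 48 h; on this read-out higher numbers stand for weaker inhibition and lower numbers for stronger inhibition:
- compound 1 `O=c1[nH]c(=O)n([C@H]2C[C@H](O)[C@@H](CO)O2)cc1[N+](=O)[O-]` gives 130 nM
- compound 2 `[N-]=[N+]=NCc1cn([C@H]2C[C@H](O)[C@@H](CO)O2)c(=O)[nH]c1=O` gives 124000 nM
- compound 3 `CS(=O)(=O)Cc1cn([C@H]2C[C@H](O)[C@@H](CO)O2)c(=O)[nH]c1=O` gives > 200000 nM as a limit, not a number

Compound 3 stands at the limit of > 200000 nM in this assay, at which 1 of the 3 values shown sits, and has no number of its own. Compound 4 `O=c1[nH]c(=O)n([C@H]2C[C@H](O)[C@@H](CO)O2)cc1C1SCCS1` carries a group of 5 heavy atoms (3 carbon, 2 sulfur; one five-membered non-aromatic ring with 2 hetero atoms) in place of a group of 5 heavy atoms (2 carbon, 2 oxygen, 1 sulfur; no ring), on an aromatic carbon and has not yet been measured. Like compound 2 and compound 3, it has no nitro group. The large steps of a 950-fold higher number from compound 1 to compound 2 (2.98 log units; beyond the scatter) and an at least 1500-fold higher number from compound 1 to compound 3 (3.18 log units; beyond the scatter) both remove nitro, so they bear on this change only indirectly. The closest parallel is an at least 1.6-fold higher number from compound 2 to compound 3 (0.20 log units; that floor lies within the scatter) with one group without nitro exchanged for another. As far as these compounds go, no step beyond the scatter is therefore expected in this assay, and the direction stays open. The estimated change is an at least 1.3-fold lower number from compound 3 to compound 4 (0.12 log units; that floor lies within the scatter) as an expectation only. For compound 4 the expected value is 150000 nM with an estimated range of 50000 nM to 400000 nM in this read-out.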

Compound 4, half-maximal inhibitory concentration: > 200000 nM
Compound 4: only a limit was reported (the forecaster's own chance of this, stated with the estimate: 50%); at least 1.3-fold (0.12 log units) between middle value and limit.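

In this assay, compound 4 brings a third group without nitro and the first with a ring on this aromatic carbon, and like compound 3 it yields only a limit, not a number: the limit of > 200000 nM in this assay, at which 2 of the 4 values shown sit. Putting the five-membered non-aromatic ring with 2 hetero atoms in place of nitro gives an at least 1500-fold higher number from compound 1 to compound 4 (3.18 log units; beyond the scatter), so the large gap seen with the azidomethyl and (methylsulfonyl)methyl groups also appears with a ring group, whereas an at least 1.6-fold higher number from compound 2 to compound 4 (0.20 log units; that floor lies within the scatter) sets no order. The step between compound 3 and compound 4 cannot be read, as both are limits.

Open, as far as these compounds go, is whether any group other than nitro at this position, such as an amine, a nitrile or a carboxylic acid, comes near compound 1 at 130 nM. Also open, from the compounds shown here alone, is how far compound 3 and compound 4 lie beyond their shared limit.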